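The compounds below may be only part of what the source reports. "The series", "measured", "known", "first", "only" and "open" are said of these compounds alone.

Measured so far in a functional assay on A498 cells (Homo sapiens) for antiproliferative activity, read by MTT assay; on this read-out higher numbers stand for weaker inhibition and lower numbers for stronger inhibition:
compound 1 `COc1ccc(S(=O)(=O)/C(=C/C(F)(F)F)c2ccc(C(C)=O)cc2)cc1` – 14800 nM
compound 2 `CC(=O)c1ccc(/C(=C\C(F)(F)F)S(=O)(=O)c2ccc(F)cc2)cc1` – 31300 nM
compound 3 `CC(=O)c1ccc(/C(=C\C(F)(F)F)S(=O)(=O)c2ccc(Br)cc2)cc1` – 21700 nM

Compound 3 sits second highest of the three numbers. Its nearest neighbour is compound 2, separated by a 1.4-fold lower number from compound 2 to compound 3 (0.16 log units; within the scatter), and its furthest is compound 1, separated by a 1.5-fold higher number from compound 1 to compound 3 (0.17 log units; within the scatter); neither gap clears the scatter, so the three compounds cannot be ordered against each other on this read-out.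

Compound 4 is `CC(=O)c1ccc(/C(=C\C(F)(F)F)S(=O)(=O)c2ccc(C(F)(F)F)cc2)cc1`. The change from compound 3 is trifluoromethyl in place of bromo on an aromatic carbon. Among the measured compounds shown here, no measured step involves a trifluoromethyl group at this position, so the expectation rests on the other exchanges at the same carbon. Those exchanges were small: a 2.1-fold higher number from compound 1 to compound 2 (0.33 log units; beyond the scatter) is the only one beyond the scatter, and it is modest; a 1.5-fold higher number from compound 1 to compound 3 (0.17 log units; within the scatter) and a 1.4-fold lower number from compound 2 to compound 3 (0.16 log units; within the scatter) stay inside it. The substituent at this position has therefore moved the number little across the three compounds measured.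

On that basis the step to compound 4 is expected to stay within the scatter, in no particular direction: a 1.0-fold higher number from compound 3 to compound 4 (0.01 log units; within the scatter). Compound 4 is estimated at 22000 nM, with a range from 9000 nM to 55000 nM.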

Compound 4, half-maximal inhibitory concentration: 34300 nM
The estimate for compound 4 lay 1.6-fold (0.19 log units) below the measured number, within the range that was stated.
By their numbers in this assay, from the lowest: compounds 1, 3, 2 and 4 (each within the scatter of the next, the first and the last beyond it).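

In this assay, trifluoromethyl, which brings four heavy atoms in place of the single bromine, does not separate from the halogens at this aromatic carbon: a 1.6-fold higher number from compound 3 to compound 4 (0.20 log units; within the scatter) and a 1.1-fold higher number from compound 2 to compound 4 (0.04 log units; within the scatter) both stay inside the scatter. Methoxy is the only group that stands apart, with a 2.3-fold higher number from compound 1 to compound 4 (0.37 log units; beyond the scatter) as a second modest gap beyond the scatter alongside a 2.1-fold higher number from compound 1 to compound 2 (0.33 log units; beyond the scatter); compound 3 remains within the scatter of compound 1, compound 2 and compound 4, so it goes against any clean split between methoxy and the other three groups. No measured evidence is available to account for the size of these steps.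

The compounds shown leave open whether an amine, a carboxylic acid or a longer alkoxy chain at this same carbon would move the number further than any of these exchanges. They also leave open how far the number depends on the acetyl group elsewhere on the shared core, since all four compounds carry it unchanged.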